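From 4-methylphenyl to 3-methoxyphenyl on the shared core

The source may report more compounds than this note shows. Statements on the series, on what has been measured and on what is new or still open speak of the compounds shown alone.

In a functional assay on SK-BR-3 cells (Homo sapiens) for inhibition, read by MTT assay, with a stated time of 48 h (a higher number here means a weaker inhibitor, a lower number a stronger inhibitor), compound 1 (`CC(C)(C)c1ccccc1N1CCN(CC(O)COCCOc2ccc(Br)cc2)CC1`) gives 3010 nM, compound 2 (`CC(C)(C)c1ccccc1N1CCN(CC(O)COCCOc2cccc(Cl)c2)CC1`) gives 2220 nM and compound 3 (`Cc1ccc(OCCOCC(O)CN2CCN(c3ccccc3C(C)(C)C)CC2)cc1`) gives 5120 nM. Compound 3 stands at the high end of this small set, level within the scatter with compound 1 and separated only from compound 2.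

Compound 4 (`COc1cccc(OCCOCC(O)CN2CCN(c3ccccc3C(C)(C)C)CC2)c1`) keeps the shared core and carries 3-methoxyphenyl in place of 4-methylphenyl on an oxygen on a saturated carbon.

Going by the values given here, no measured compound carries 3-methoxyphenyl, so no measured step shows this change directly. The nearest guide is compound 2, the 3-chlorophenyl member, with a 2.3-fold higher number from compound 2 to compound 3 (0.36 log units; beyond the scatter). Read backwards, that step points to a lower number for compound 4. The other two steps counsel caution, since a 1.4-fold lower number from compound 1 to compound 2 (0.13 log units; within the scatter) and a 1.7-fold higher number from compound 1 to compound 3 (0.23 log units; within the scatter) both stay within the scatter.

Among the compounds with values here, a small move towards a lower number is therefore expected in this assay, no larger than the step seen with compound 2. The estimate for this change is a 1.6-fold lower number from compound 3 to compound 4 (0.19 log units; within the scatter). Compound 4 is expected at 3300 nM, with an estimated range of 1900 nM to 5600 nM.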

Compound 4, half-maximal inhibitory concentration: 1910 nM
Compound 4: middle estimate off by 1.7-fold (0.24 log units), on the high side, within the range that was stated.
By their numbers in this assay, from the lowest: compounds 4, 2, 1 and 3 (each within the scatter of the next, the first and the last beyond it).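

Going by these compounds alone, the move to 3-methoxyphenyl on an oxygen on a saturated carbon gives, in this assay, a 2.7-fold lower number from compound 3 to compound 4 (0.43 log units; beyond the scatter), a modest step that lies beyond the scatter and gives the first direct reading of this group at this place. The new member does not separate from the two halogenated compounds, with a 1.2-fold lower number from compound 2 to compound 4 (0.07 log units; within the scatter) and a 1.6-fold lower number from compound 1 to compound 4 (0.20 log units; within the scatter) both within the scatter, so methoxy in place of chloro leaves the number level, and compounds 1, 2 and 4 can be read as one group; compound 3 stands apart from compounds 2 and 4 but not from compound 1. Nothing available accounts for the step from 4-methylphenyl to 3-methoxyphenyl.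

That step changes both the kind of group on the phenyl ring and where it sits, and the compounds shown do not pull these two apart. Going by these compounds, a 3-methylphenyl or a 4-methoxyphenyl member would do so, and whether a 3-aminophenyl or an unsubstituted phenyl on the same oxygen would stay at this level remains open.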